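The source may hold more compounds than are shown below. What is called first, only, known or untested is meant among the compounds shown, and "the series" means these compounds.

Measured so far in this series:
compound 1 `CC(C)(C)c1ccc(C/N=C(\S)NCc2ccc(NS(C)(=O)=O)c(O)c2)cc1`, 750 nM
compound 2 `CC(C)(C)c1ccc(C/N=C(\S)NCc2ccc(NS(C)(=O)=O)cc2F)cc1`, 215 nM
compound 3 `CC(C)(C)c1ccc(C/N=C(\S)NCc2ccc(CNS(C)(=O)=O)cc2)cc1`, 6120 nM

All three were characterised in an assay on CHO cells for binding affinity to transient receptor potential cation channel subfamily V member 1 (Rattus norvegicus); a higher number here means a weaker inhibitor, a lower number a stronger inhibitor. Compound 3 carries the highest number of the three. Its nearest neighbour is compound 1, which in this assay gives 750 nM, a gap beyond the scatter; compound 2 gives 215 nM, the widest gap of the set. Compounds 1 and 2 both attach the sulfonamide nitrogen directly to the ring, whereas compound 3 interposes a methylene.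

Compound 4 `CC(C)(C)c1ccc(C/N=C(\S)NCc2ccc(NS(=O)(=O)CCN)cc2)cc1` is the next target. It differs from compound 3 as follows: ((2-aminoethyl)sulfonyl)amino in place of (methanesulfonamido)methyl on an aromatic carbon. Compound 4 thereby returns to a sulfonamide nitrogen bound directly to the ring, while the sulfur now carries a 2-aminoethyl chain instead of methyl and the ring carries no other substituent. For the measured compounds named here, no pair among the measured compounds isolates this exact change, so the expected step rests on the gap between compound 3 and compounds 1 and 2. A decrease of the number, well beyond the scatter, is expected from compound 3 to compound 4, namely a 12-fold lower number from compound 3 to compound 4 (1.09 log units; beyond the scatter). Compound 4 is therefore estimated at 500 nM in this assay, with a plausible range from 100 nM to 3000 nM.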

Compound 4, inhibition constant: 4640 nM
For compound 4 the middle estimate is 9.3-fold (0.97 log units) below the measured one; measured number outside the range, above it.
By their numbers in this assay, from the lowest: compound 2; then compound 1; then compounds 4 and 3 (each within the scatter of the next).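

In this assay the exchange of (methanesulfonamido)methyl for ((2-aminoethyl)sulfonyl)amino on the aromatic carbon para to a large group gives a 1.3-fold lower number from compound 3 to compound 4 (0.12 log units; within the scatter), so the two groups cannot be told apart at this position in this read-out. This single step combines two alterations, placing the sulfonamide nitrogen directly on the ring and replacing methyl on sulfur with a 2-aminoethyl chain, and it cannot show whether each alteration has little effect or whether their effects offset one another. No measurement at hand bears on the reason for this result.

From the compounds shown here alone, the separate contribution of each alteration remains open, as a ring-bound methanesulfonamide with no other ring substituent would be needed to divide the step into its two parts. Going by these compounds, how a longer chain on sulfur, a dimethylamino group or a carboxylic acid at the end of the chain in place of the primary amine would read in this assay remains open as well.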